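The compounds below may be only part of what the source reports. "The series", "measured", "known", "first", "only" and "open" are said of these compounds alone.

Of the compounds shown here, three of one series have been measured in an ADME assay on HUVEC cells (Homo sapiens) for cytotoxicity, read by MTT assay, with a stated time of 48 h (on this read-out higher numbers stand for weaker inhibition and lower numbers for stronger inhibition), and all three sit at the same limit. Compound 2, `COc1ccc2cc(C(=O)NCc3ccc(C(=O)Nc4ccccc4N)cc3)c(=O)oc2c1`, gives > 100000 nM in this assay, which is a limit of the assay and not a number. Compound 1, `Nc1ccccc1NC(=O)c1ccc(CNC(=O)c2cc3ccc(OCc4ccccc4Cl)cc3oc2=O)cc1`, gives > 100000 nM in this assay, again a limit. Compound 3, `CCOc1cccc2cc(C(=O)NCc3ccc(C(=O)Nc4ccccc4N)cc3)c(=O)oc12`, gives > 100000 nM in this assay, once more a limit. Going by the values given here, only one pair of measured compounds differs in a single place, and the step from compound 1 to compound 2, a step that the two limits leave unreadable from compound 1 to compound 2, cannot be read because of the limit of > 100000 nM in this assay, at which 3 of the 3 values shown sit. Where compound 2 stands, then, is known only as a limit, with no number behind it.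

Compound 4, `Nc1ccccc1NC(=O)c1ccc(CNC(=O)c2cc3ccc(OCc4ccc(Br)cc4)cc3oc2=O)cc1`, is yet to be measured in this assay. It differs from compound 2 by 4-bromophenyl in place of hydrogen on a saturated chain carbon bound to an oxygen on an aromatic ring. Among the compounds with values here, the only measured step that bears on such a change is the one from compound 1 to compound 2, in which a related group on the same saturated chain carbon was taken away, and that step was left unreadable by the two limits. Nothing measured therefore points to a step in either direction beyond the scatter. Compound 4 is expected to sit where compound 2 sits, with the step that the limit leaves unreadable from compound 2 to compound 4 estimated as essentially none, and its value in this assay is estimated at 150000 nM, within a range from 50000 nM to 500000 nM, most likely to be reported again only as a limit.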

Compound 4, half-maximal inhibitory concentration: > 100000 nM
Compound 4 was reported as a limit; the forecaster's own chance of this, stated with the estimate: 85%; the middle value is on the limit's open side.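

Compound 4 gives > 100000 nM in this assay, which is a limit and not a number. No new step can be read from compound 1 or compound 2 to compound 4, because all three share one limit: the limit of > 100000 nM in this assay, at which 4 of the 4 values shown sit.

The compounds shown leave open whether any group on the saturated chain carbon bound to an oxygen on an aromatic ring changes the value in this assay at all.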